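Swapping Methoxy for Tert-Butyl: What the Numbers Suggest

This account rests on a few compounds, and the source may have more. Where it says the series, first, only, none or still open, it means among the compounds named here.

Three related compounds have been measured so far. In a functional assay on THP-1 cells (Homo sapiens) for cytotoxicity, read by MTT assay, with a stated time of 24 h (on this read-out higher numbers stand for weaker inhibition and lower numbers for stronger inhibition), compound 1 `COc1ccc(/C=C2\CN(C)C/C(=C\c3ccccc3F)C2=O)cc1` gives 15400 nM. Compound 2 `COc1ccc(/C=C2\CN(C)C/C(=C\c3ccccc3F)C2=O)cc1OC` gives 11200 nM, and compound 3 `COc1cc(/C=C2\CN(C)C/C(=C\c3ccccc3F)C2=O)cc(OC)c1` gives 1170 nM. Compound 1 therefore sits in the high group together with compound 2, while compound 3 has a clearly lower number.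

The unmeasured compound 4 `CN1C/C(=C\c2ccc(C(C)(C)C)cc2)C(=O)/C(=C/c2ccccc2F)C1` keeps the core of compound 1 and changes one group: tert-butyl in place of methoxy on an aromatic carbon, para to a large group (tert-butyl in place of methoxy on an aromatic carbon).

Within the data shown here, no measured step makes this exact swap. The closest one also alters a group on an aromatic carbon, with methoxy in place of hydrogen, and it is small: a 1.4-fold lower number from compound 1 to compound 2 (0.14 log units; within the scatter). That makes it only a loose guide. Compound 3 at 1170 nM shows that a different arrangement of methoxy groups can go with a much lower number, so the range has to stay wide, especially on the low side.

On this evidence, no change beyond the scatter is expected in this assay, and the estimated step is a 1.7-fold lower number from compound 1 to compound 4 (0.23 log units; within the scatter). Compound 4 is estimated at 9000 nM, with an expected range from 2000 nM to 30000 nM.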

Compound 4, half-maximal inhibitory concentration: 13400 nM
The estimate for compound 4 lay 1.5-fold (0.17 log units) below the measured number, and the stated range covers the measured number.
By their numbers in this assay, from the lowest: compound 3; then compounds 2, 4 and 1 (each within the scatter of the next).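

In this assay, tert-butyl in place of methoxy, on an aromatic carbon para to a large group, gives a 1.1-fold lower number from compound 1 to compound 4 (0.06 log units; within the scatter). The earlier step showed only that adding a second methoxy to the ring left the number within the scatter, whereas this one removes the methoxy of compound 1 altogether: at this place, methoxy with its 1 hydrogen-bond acceptor and the bigger tert-butyl with 0 give numbers that cannot be told apart. Nothing among the available data accounts for this match between the two groups.

As far as these compounds go, both groups here are uncharged, so it remains open whether an amine or a carboxylic acid at this same place would also leave the number unchanged. From the compounds shown here alone, it is also open whether tert-butyl would go with a low number if placed on the ring in the arrangement that the methoxy groups of compound 3 take, since that arrangement, rather than this position, is what accompanies the clearly lower number so far.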